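A few compounds are considered here, and "the series" means these few. Any claim that something is new, unique, unknown or untested is made for them only; others in the source may bear on it.

Of the compounds shown here, three sharing one core have been tested in a functional assay on the whole organism for inhibition, with Rattus norvegicus as the target; a lower number here means that less compound is needed, a higher number that more compound is needed for the effect. Compound 1 `CC1CC/C(=N\Nc2ccccc2)c2ncc(C(=O)NN)c(=O)n21` reaches only a limit of the assay, > 1000 umol/kg, and so gives no number. Compound 2 `O=C(O)c1cnc2n(c1=O)CCC/C2=N\Nc1ccccc1` likewise reaches only a limit, > 100 umol/kg. Going by the values given here, compound 3 `CC1CC/C(=N\Nc2cccc(I)c2)c2ncc(C(=O)O)c(=O)n21` is the one compound with an actual value, 1000 umol/kg. Among the compounds with values here, it is thus the only measured number among the three. Compound 4 `Cc1cccc(N/N=C2\CCC(C)n3c2ncc(C(=O)O)c3=O)c1` differs from compound 3 by a single change: methyl in place of iodo on an aromatic carbon. Within the data shown here, no step between two measured compounds exists here against which this change can be weighed. A step of no change at the digits printed from compound 3 to compound 4 (within the scatter) is expected, within the usual scatter and with no clear direction. For compound 4 the estimate is 1000 umol/kg, within 300 umol/kg to 3000 umol/kg.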

Compound 4, dose for 50% inhibition: 72.5 umol/kg
Compound 4: middle estimate off by 14-fold (1.14 log units), on the high side; measured number below the stated range.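

Swapping iodo for methyl on the aromatic carbon meta to a large group gives a 14-fold lower number from compound 3 to compound 4 (1.14 log units; beyond the scatter) in this assay. Going by these compounds alone, this is the first step that can be read, and it shows that this place on the ring matters: one small change moves the dose well beyond the scatter. Nothing measured here explains why the swap has so large an effect.

The compounds shown leave open how other groups at this place, such as chloro, methoxy or an amine, would compare with methyl. They also leave open whether the same swap would have a similar effect on a different core.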